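Ether substituent on the shared core: compound 3 to compound 4

The source may hold more compounds than are shown below. What is called first, only, known or untested is meant among the compounds shown, and "the series" means these compounds.

compound 1 `O=C(N[C@@H]1CCNC1)c1cc(-c2ccc(NS(=O)(=O)c3cccc(Cl)c3Cl)cc2)nc2[nH]ncc12`: < 1 nM
compound 2 `Cc1n[nH]c2nc(-c3ccc(NS(=O)(=O)c4cc(Cl)ccc4F)cc3)nc(OCC3(CN)COC3)c12`: 1 nM
compound 3 `Cc1n[nH]c2nc(-c3ccc(NS(=O)(=O)c4cc(Cl)ccc4F)cc3)nc(OC3CCOCC3)c12`: 14 nM

In an assay for inhibition of serine/threonine-protein kinase Sgk1 (Homo sapiens), with stated times of 30 min and 60 min, in the presence of a further agent that is not named here (on this read-out lower numbers stand for stronger inhibition and higher numbers for weaker inhibition), compound 1 gives < 1 nM, which is a limit of the assay (the limit of < 1 nM in this assay, at which 1 of the 3 values shown sits). Compound 2 gives 1 nM in this assay. Compound 3 gives 14 nM, the highest of the two numbers shown. Within the data shown here, the only measured step at the oxygen on the aromatic ring is a 14-fold higher number from compound 2 to compound 3 (1.15 log units; beyond the scatter), a large one. Compound 4 `Cc1n[nH]c2nc(-c3ccc(NS(=O)(=O)c4cc(Cl)ccc4F)cc3)nc(OC3CC(C)(C)N(C)C(C)(C)C3)c12` differs from compound 3 by 1,2,2,6,6-pentamethylpiperidin-4-yl in place of oxan-4-yl on an oxygen on an aromatic ring. Among the measured compounds shown here, no measured step covers this particular exchange, so the size of the step is uncertain in either direction; a change comparable to the one step seen at this oxygen is plausible. Compound 4 is expected to give 5 nM (range 1 nM to 30 nM), an estimated step of a 2.8-fold lower number from compound 3 to compound 4 (0.45 log units; beyond the scatter).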

Compound 4, half-maximal inhibitory concentration: 3 nM
Compound 4: middle estimate off by 1.7-fold (0.22 log units), on the high side; low and high end bracket the measured number.
By their numbers in this assay, from the lowest: compound 2; then compound 4; then compound 3.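

In this assay, the oxygen on the aromatic ring accepts 1,2,2,6,6-pentamethylpiperidin-4-yl with a better result than oxan-4-yl (a 4.7-fold lower number from compound 3 to compound 4 (0.67 log units; beyond the scatter)). Of the three ether substituents, (3-(aminomethyl)oxetan-3-yl)methyl still gives the lowest number (a 3.0-fold higher number from compound 2 to compound 4 (0.48 log units; beyond the scatter)). Both nitrogen-bearing groups give lower numbers than oxan-4-yl, a pattern resting on these three compounds alone.

On these data alone, whether the ring nitrogen or the methyl groups carry the step remains open, and plain piperidin-4-yl would separate the two. Nothing shown here bears on the reason for these steps.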